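The source may hold more compounds than are shown below. What is called first, only, known or untested is meant among the compounds shown, and "the series" means these compounds.

Measured compounds:
Compound 1, `Cc1cccc(N2C(=O)CSC2c2cccc(C(=O)NCCCCc3ccccc3)c2)c1`, in an ADME assay on microsomes from liver (Homo sapiens) for metabolic stability, read by LC-MS, using NADPH, with a stated time of 10 min, tested at 0.1 uM (a lower number here means slower removal, a higher number faster removal of the compound), gives 2550 mL.min-1.g-1.
Compound 2, `Cc1ccnc(N2C(=O)CSC2c2cccc(C(=O)NCCCCn3cccn3)c2)c1`, in this assay gives 129 mL.min-1.g-1.
Compound 3, `O=C(NCCCCc1ccccc1)c1cccc(C2SCC(=O)N2c2cccc(F)c2)c1`, in this assay gives 1840 mL.min-1.g-1.

Compound 1 and compound 3 share a core and differ in one place: fluoro in place of methyl on an aromatic carbon. That change gave a 1.4-fold lower number from compound 1 to compound 3 (0.14 log units; within the scatter), so the two numbers cannot be told apart. Compound 2 is built on a different core; how its core differs from that of compound 1 is not broken down here. In this assay compound 2 stands well apart from both, with compound 3 and compound 1 showing numbers that lie beyond the scatter above it.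

Compound 4, `O=C(NCCCCn1cccn1)c1cccc(C2SCC(=O)N2c2cc(F)ccn2)c1`, has not yet been measured in this assay. It is made from compound 2 by fluoro in place of methyl on an aromatic carbon. Among the measured compounds shown here, this is the same kind of change as the one from compound 1 to compound 3, but the place is not the same: in compound 2 the ring is a six-membered aromatic ring with 1 nitrogen and the carbon is opposite the ring nitrogen, whereas in compound 1 it is a six-membered aromatic ring of carbon only.

Because the earlier change gave a 1.4-fold lower number from compound 1 to compound 3 (0.14 log units; within the scatter), the step from compound 2 to compound 4 is expected to be small, about a 1.3-fold lower number from compound 2 to compound 4 (0.11 log units; within the scatter). Compound 4 is therefore estimated at 100 mL.min-1.g-1 in this assay, with a range from 50 mL.min-1.g-1 to 200 mL.min-1.g-1.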

Compound 4, intrinsic clearance in microsomes in the Homo sapiens assay: 116 mL.min-1.g-1
Estimate against measurement, compound 4: 1.2-fold (0.06 log units) below; the measured number falls inside the stated range.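

In the Homo sapiens assay compound 4 gives 116 mL.min-1.g-1 and the new step is a 1.1-fold lower number from compound 2 to compound 4 (0.05 log units; within the scatter), and set beside the earlier one it shows that fluoro in place of methyl on an aromatic carbon carried over from one core to the other without a step that can be told from the scatter, whether the ring held a ring nitrogen or carbon only: the same change on two cores in the Homo sapiens assay, a 1.4-fold lower number (0.14 log units; within the scatter) from compound 1 to compound 3 and a 1.1-fold lower number (0.05 log units; within the scatter) from compound 2 to compound 4, 1.2-fold (0.10 log units) apart, within the scatter of two such steps
On the core of compound 2 the same change also left a physicochemical assay for solubility, read by turbidimetry, measured as kinetic solubility, at pH 6.8 (a higher number here means a more soluble compound, a lower number a less soluble compound), flat, with no change at the digits printed from compound 2 to compound 4 (within the scatter), compound 2 giving 50000 nM and compound 4 giving 50000 nM.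
This agreement rests on two pairs only, and since neither step in the Homo sapiens assay leaves the scatter, it shows that the swap was silent on these two cores, not that it would be silent on any other core or that a change with a larger step would carry over in the same way.

The compounds shown leave open what happens when something other than fluoro takes the place of the methyl on the ring, such as a trifluoromethyl group, a nitrile or an amine. They also leave open whether a shorter or longer chain on the amide nitrogen, or a carboxylic acid at its end, would move the number in the Homo sapiens assay beyond the scatter.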